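Swapping Methoxy for Methoxycarbonyl on Compound 1

The source may hold more compounds than are shown below. What is called first, only, known or untested is meant among the compounds shown, and "the series" means these compounds.

Compound 1 `CCOC(=O)C(=O)Nc1nc(-c2ccccc2OC)cs1` is tested in a functional assay on the whole organism with Rattus norvegicus as the target; on this read-out lower numbers stand for an effect already at smaller amounts and higher numbers for an effect only at larger amounts of compound. Compound 1 gives > 30 mg/kg, which is a limit of the assay and not a number. Compound 2 `CCOC(=O)C(=O)Nc1nc(-c2ccc(N(C)C)cc2)cs1` gives a real number, about 1 mg/kg. Compound 3 `CCOC(=O)C(=O)Nc1nc(-c2ccccc2C(=O)OC)cs1` keeps the core of compound 1 but carries methoxycarbonyl in place of methoxy on an aromatic carbon. Compound 1, with its limit of > 30 mg/kg, is the closer guide, as the change sits at the same place on the ring. The expected step of a number no higher from compound 1 to compound 3 (the limit leaves the size open) is none beyond the scatter. For compound 3 the estimated value is 30 mg/kg, with an expected range of 8 mg/kg to 100 mg/kg.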

Compound 3, dose for half-maximal effect: > 10 mg/kg
Compound 3 ended at the assay's limit; the forecaster's own chance of this, stated with the estimate: 60%; the middle value is on the limit's open side.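

No step can be read from compound 1 to compound 3: in this assay both values are limits, not numbers. The compounds shown leave open whether methoxy or methoxycarbonyl gives the lower dose for half-maximal effect, and by how much.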